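The source may hold more compounds than are shown below. What is called first, only, known or untested is meant among the compounds shown, and "the series" means these compounds.

Three measured compounds share one core. Compound 1 `O=C(/C=C/c1ccc(OCc2nc(C3CCN(Cc4ccccc4)CC3)no2)cc1)NO` in an assay on isolated protein for inhibition of protein deacetylase HDAC6 (Homo sapiens), read by fluorescence, with a stated time of 1 h, tested at 100 nM (on this read-out higher numbers stand for more inhibition at the one concentration tested (going by the name of the read-out) and lower numbers for less inhibition), gives 71%. Compound 2 `Cc1ccccc1CN1CCC(c2noc(COc3ccc(/C=C/C(=O)NO)cc3)n2)CC1` gives 68% in this assay, and compound 3 `O=C(/C=C/c1ccc(OCc2nc(C3CCN(Cc4ccc(F)cc4)CC3)no2)cc1)NO` gives 75% in this assay. Compound 3 stands highest of the three numbers, yet the gap to it from compound 1, a number 4 percentage points higher from compound 1 to compound 3 (within the scatter), and the gap to it from compound 2, a number 7 percentage points higher from compound 2 to compound 3 (within the scatter), both lie within the scatter, so the three numbers cannot be ordered. The step to the unmeasured compound 4 `O=C(/C=C/c1ccc(OCc2nc(C3CCN(Cc4ccc(F)cc4F)CC3)no2)cc1)NO` is fluoro in place of hydrogen on an aromatic carbon. Among the compounds with values here, two measured steps bear on it: the fluoro in place of hydrogen on an aromatic carbon gave a number 4 percentage points higher from compound 1 to compound 3 (within the scatter), and the methyl in place of hydrogen on an aromatic carbon gave a number 3 percentage points lower from compound 1 to compound 2 (within the scatter), both within the scatter. Neither group added to this ring has moved this assay beyond the scatter, so the step of no change at the digits printed from compound 3 to compound 4 (within the scatter) is expected to stay within it as well, with no direction called. Compound 4 is therefore estimated at 75% in this assay, with a range from 62% to 86%.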

Compound 4, a percentage reported as inhibition, at one concentration (the size of the read-out at that concentration, not a potency): 74%
The estimate for compound 4 lay 1 percentage points above the measured number, within the range that was stated.
By their numbers in this assay, from the lowest: compounds 2, 1, 4 and 3 (each within the scatter of the next).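

Compound 4 is the first case shown with a second fluoro on this ring, on an aromatic carbon ortho to a large group and meta to a fluoro group, and a number 1 percentage points lower from compound 3 to compound 4 (within the scatter) in this assay shows that this addition to 4-fluorobenzyl does not carry the number beyond the scatter. The 2,4-difluorobenzyl group also stays within the scatter of the other two benzyl groups, with a number 3 percentage points higher from compound 1 to compound 4 (within the scatter) and a number 6 percentage points higher from compound 2 to compound 4 (within the scatter) as the readings, so all four compounds remain unordered and the ring has so far taken one fluoro, two fluoro groups or a methyl without a step that can be read as a change. No measurement is available that would account for this flat outcome.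

As far as these compounds go, whether a larger or ionisable group on this ring, such as a carboxylic acid, an amine or a longer chain, would move the number beyond the scatter remains open. Also open, from the compounds shown here alone, is whether these compounds differ at other concentrations, as this assay gives the size of the inhibition at a single concentration and not a potency.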